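Shortening the Sulfur-Linked Chain by One Carbon

The source may hold more compounds than are shown below. What is called first, only, known or untested is meant among the compounds shown, and "the series" means these compounds.

Going by the values given here, compound 1, `CCCCCCSc1nnc(COc2ccc3c(c2)CCC(=O)N3)o1`, is one of two compounds measured in a functional assay on the whole organism (strain Kunming) with Mus musculus as the target, with a stated time of 30 min; a lower number here means that less compound is needed, a higher number that more compound is needed for the effect. In this assay compound 1 gives 17.9 mg/kg. The other measured compound, compound 2, `CCCCCCSc1nnc(COc2ccc(NC(C)=O)cc2)o1`, carries the same sulfur-linked chain on the shared core but a different aromatic part; in this assay compound 2 gives 26.8 mg/kg. Compound 1 stands at one end of these two numbers, yet the gap to compound 2 lies within the usual scatter of repeated measurements, so the two cannot be told apart on the evidence so far.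

Compound 3, `CCCCCSc1nnc(COc2ccc3c(c2)CCC(=O)N3)o1`, has not yet been measured. It differs from compound 1 by a single change: hydrogen in place of methyl on a saturated chain carbon, five bonds along the chain from a sulfur. No measured pair among these compounds shows a step of this kind, so there is no direct precedent to lean on. With one chain carbon removed and nothing else touched, the expected change is modest: the step of a 1.1-fold higher number from compound 1 to compound 3 (0.05 log units; within the scatter) is estimated to stay within the scatter, in no firm direction. Compound 3 is therefore expected to give about 20 mg/kg, with a likely range from 10 mg/kg to 40 mg/kg.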

Compound 3, dose for half-maximal effect: 10.2 mg/kg
For compound 3 the middle estimate is 2.0-fold (0.29 log units) above the measured one; the measured number falls inside the stated range.
By their numbers in this assay, from the lowest: compounds 3, 1 and 2 (each within the scatter of the next, the first and the last beyond it).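

Going by these compounds alone, this pair gives the first direct reading of the sulfur-linked chain. Compounds 1 and 3 differ only by hydrogen in place of methyl on a saturated chain carbon, five bonds along the chain from a sulfur. In this assay, that one change gives a 1.8-fold lower number from compound 1 to compound 3 (0.24 log units; within the scatter), so the two compounds cannot be told apart and the chain can lose this one carbon with no measurable change in the dose needed for the effect. Nothing available explains this outcome at the level of the molecule, and a number that stays within the scatter would give little to explain in any case.

The compounds shown leave open how far this tolerance reaches: a longer chain, a much shorter one, or a chain carrying an amine or a carboxylic acid could each behave differently in this assay. Going by these compounds, it also remains unknown whether removing the same carbon would have a similarly small effect when the aromatic part of compound 2 is present instead of that of compound 1.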